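Benzyl in Place of Hydrogen on the Phenyl Ring

The compounds below may be only part of what the source reports. "The series", "measured", "known", "first", "only" and "open" are said of these compounds alone.

In a functional assay on aorta for antagonist activity at Alpha-1D adrenergic receptor (Rattus norvegicus) (on this read-out lower numbers stand for tighter binding and higher numbers for weaker binding), compound 1 `COc1ccccc1N1CCN(CCCNc2ncccc2C(=O)NC(C)(C)C)CC1` gives 10 nM. Compound 2 `CN(C)C(=O)c1cccnc1NCCCN1CCN(c2ccccc2)CC1` gives 15.9 nM in this assay, a number that lies within the usual scatter of the value of compound 1, so the two cannot be told apart. Compound 3 `CN(C)C(=O)c1cccnc1NCCCN1CCN(c2ccccc2Cc2ccccc2)CC1` has not yet been measured. It differs from compound 2 in a single place: benzyl in place of hydrogen on an aromatic carbon. Among the measured compounds shown here, no measured pair shows what this kind of change does here. A moderate step toward weaker binding, a 2.5-fold higher number from compound 2 to compound 3 (0.40 log units; beyond the scatter), is expected. Compound 3 is therefore estimated at 40 nM, with a range from 10 nM to 160 nM.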

Compound 3, dissociation constant: 79.4 nM
The estimate for compound 3 lay 2.0-fold (0.30 log units) below the measured number; low and high end bracket the measured number.
By their numbers in this assay, from the lowest: compounds 1 and 2 (each within the scatter of the next); then compound 3.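

In this assay benzyl in place of hydrogen gives a 5.0-fold higher number from compound 2 to compound 3 (0.70 log units; beyond the scatter) and so provides the first measured sign that a change on this aromatic carbon, ortho to a large group, can move the number beyond the scatter toward weaker binding. Binding is weakened but not lost. No measurement shown gives a reason for this step.

Still open, from the compounds shown here alone, is whether methyl or fluorine on this same carbon would leave the number close to that of compound 2. Also open, going by these compounds, is how an amine or a carboxylic acid on the added benzyl ring would alter the step.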